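Three thiourea sulfonamides and a catechol analogue awaiting measurement

A few compounds are considered here, and "the series" means these few. Any claim that something is new, unique, unknown or untested is made for them only; others in the source may bear on it.

Measured so far:
compound 1 `O=[N+]([O-])c1ccc(NC(=S)NCCNS(=O)(=O)c2ccc(-c3ccccc3OCc3ccccc3)s2)cc1` gives 8900 nM in an ADME assay on HEK-293T cells (Homo sapiens) for cytotoxicity, read by CCK-8 assay, with a stated time of 48 h; on this read-out higher numbers stand for weaker inhibition and lower numbers for stronger inhibition;
compound 2 `O=S(=O)(NCCNC(=S)Nc1cc(C(F)(F)F)cc(C(F)(F)F)c1)c1ccc(-c2ccccc2OCc2ccccc2)s1` gives 8500 nM in this assay;
compound 3 `O=[N+]([O-])c1ccc(Oc2ccccc2-c2ccc(S(=O)(=O)NCCNC(=S)Nc3cc(C(F)(F)F)cc(C(F)(F)F)c3)s2)cc1` gives 6000 nM in this assay.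

The three numbers form a tight cluster. For the measured compounds named here, compound 3 has the smallest of them, but its separation from compound 2 and from compound 1 lies within the scatter, so no compound can be called more or less cytotoxic than another on these data.

Going by the values given here, only one step joins two measured compounds: a 1.4-fold lower number from compound 2 to compound 3 (0.15 log units; within the scatter). Among the compounds with values here, it is the only precedent for changing the group on the oxygen on the aromatic ring, and it shows that swapping a benzyl for a 4-nitrophenyl at that place left the number essentially where it was.

Compound 4 `O=S(=O)(NCCNC(=S)Nc1cc(C(F)(F)F)cc(C(F)(F)F)c1)c1ccc(-c2ccccc2Oc2ccc(O)c(O)c2)s1` has not been measured. It differs from compound 3 as follows: 3,4-dihydroxyphenyl in place of 4-nitrophenyl on an oxygen on an aromatic ring. Within the data shown here, no measured pair speaks to a 3,4-dihydroxyphenyl at this place, so the expectation for compound 4 rests on the single earlier step, which was within the scatter. Compound 4 is therefore expected to stay close to compound 3, with the estimated step of a 1.2-fold higher number from compound 3 to compound 4 (0.07 log units; within the scatter) not exceeding the scatter.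

Compound 4 is estimated at 7000 nM, with a range from 3000 nM to 16000 nM.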

Compound 4, half-maximal inhibitory concentration: 12300 nM
For compound 4 the middle estimate is 1.8-fold (0.24 log units) below the measured one, within the range that was stated.
By their numbers in this assay, from the lowest: compounds 3, 2, 1 and 4 (each within the scatter of the next, the first and the last beyond it).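

In this assay, a change of the group on an oxygen on an aromatic ring now gives a step beyond the scatter, though a modest one: a 2.1-fold higher number from compound 3 to compound 4 (0.31 log units; beyond the scatter) when 3,4-dihydroxyphenyl replaces 4-nitrophenyl. The same group does not separate from benzyl at this place, with a 1.4-fold higher number from compound 2 to compound 4 (0.16 log units; within the scatter) staying within the scatter, so the position responds measurably only in the comparison of 3,4-dihydroxyphenyl with 4-nitrophenyl, and the three groups do not fall into a clear order. Nothing available gives a reason for the step from 4-nitrophenyl to 3,4-dihydroxyphenyl.

The compounds shown leave open whether both hydroxyl groups of the 3,4-dihydroxyphenyl are needed for this step, or whether a single hydroxyl, a methoxy group, an amine or a carboxylic acid on the same phenyl ring would give a similar number. They also leave open whether the step would persist with the 4-nitrophenyl on the thiourea, as in compound 1, in place of the bis(trifluoromethyl)phenyl group of compound 3 and compound 4.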